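This account rests on a few compounds, and the source may have more. Where it says the series, first, only, none or still open, it means among the compounds named here.

Measured in a functional assay on HCT-116 cells (Homo sapiens), read by MTT assay, with a stated time of 72 h; on this read-out higher numbers stand for weaker inhibition and lower numbers for stronger inhibition:

- Compound 1 `C#Cc1cn([C@@H]2O[C@H](CO)[C@@H](O)[C@H]2O)c2ncnc(OC)c12`: 5140 nM
- Compound 2 `CSc1ncnc2c1c(-c1ccoc1)cn2[C@@H]1O[C@H](CO)[C@@H](O)[C@H]1O`: 100 nM
- Compound 3 `CSc1ncnc2c1c(-c1ccsc1)cn2[C@@H]1O[C@H](CO)[C@@H](O)[C@H]1O`: > 20000 nM, which is a limit of the assay and not a number

Compound 3 stands at the limit of > 20000 nM in this assay, at which 1 of the 3 values shown sits. Compound 4 `C#Cc1cn([C@@H]2O[C@H](CO)[C@@H](O)[C@H]2O)c2ncnc(SC)c12` keeps everything in compound 3 except one group: ethynyl in place of thiophen-3-yl on an aromatic carbon. Ethynyl thus takes the place of thiophen-3-yl on an aromatic carbon.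

Within the data shown here, one measured step concerns the same carbon: an at least 200-fold higher number from compound 2 to compound 3 (2.30 log units; beyond the scatter), where thiophen-3-yl stands in place of furan-3-yl. This step is large, so the group on this carbon can clearly shift the result in this assay a long way. It does not show what ethynyl will do, however.

The nearest guide is compound 1, which carries ethynyl on the same carbon but has methoxy where compound 4 has methylthio. Compound 1 gives 5140 nM, a real number rather than a limit. On that basis, the value for compound 4 is expected to be a real number in the same region, with a wide margin of doubt.

The expected change is an at least 11-fold lower number from compound 3 to compound 4 (1.04 log units; beyond the scatter), a large move towards stronger inhibition. For compound 4 the estimated value is 1800 nM, with an expected range from 200 nM to 15000 nM.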

Compound 4, half-maximal inhibitory concentration: 90 nM
For compound 4 the middle estimate is 20-fold (1.30 log units) above the measured one; the measured number lies below the stated range.
By their numbers in this assay, from the lowest: compounds 4 and 2 (each within the scatter of the next); then compound 1. At a limit, above all of these: compound 3.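

In this assay, ethynyl, which has no ring, and furan-3-yl, a five-membered aromatic ring, give results that cannot be told apart on this carbon when methylsulfanyl is held constant: a 1.1-fold lower number from compound 2 to compound 4 (0.05 log units; within the scatter). Thiophen-3-yl alone stands apart among the three groups seen with methylsulfanyl, as an at least 220-fold lower number from compound 3 to compound 4 (2.34 log units; beyond the scatter) shows, and this step rests on a limit of the assay for compound 3, not on a number: the limit of > 20000 nM in this assay, at which 1 of the 4 values shown sits. Ethynyl alone does not set the result either, since a 57-fold lower number from compound 1 to compound 4 (1.76 log units; beyond the scatter) with methylsulfanyl in place of methoxy on an aromatic carbon and ethynyl unchanged, so the group at that second place counts for a great deal.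

The compounds shown do not explain why thiophen-3-yl and furan-3-yl, two similar-looking rings, part so widely, nor whether methoxy would cost as much with either ring in place of ethynyl. From the compounds shown here alone, it also stays open what an amine, a carboxylic acid or a longer chain such as propynyl would do on this carbon.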